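The source may report more compounds than this note shows. Statements on the series, on what has been measured and on what is new or still open speak of the compounds shown alone.

Working notes on the series.

Of the compounds shown here, two have been measured. Compound 1 `Fc1ccc(-c2cn3ccnc3c(-c3ccc4ncn(C5CCCCC5)c4c3)n2)cc1` carries a 4-fluorophenyl group; in a functional assay on NCI-H226 cells (Homo sapiens) for inhibition, read by sulforhodamine B assay, with a stated time of 48 h, tested at 10 uM (a higher number here means more inhibition at the concentration tested (going by the name of the read-out), a lower number less inhibition), compound 1 gives 23.3%. Compound 2 `Fc1ccccc1-c1cn2ccnc2c(-c2ccc3ncn(C4CCCCC4)c3c2)n1` carries the fluorine in the 2-position of the phenyl ring; in this assay compound 2 gives 28.7%. Going by the values given here, the single step between them, a number 5.4 percentage points higher from compound 1 to compound 2 (within the scatter), moves the fluorine around the ring without taking the read-out beyond the scatter. Compound 2 therefore stands with the higher of the two numbers, but its gap to compound 1 is not a real difference on these data.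

Compound 3 `c1csc(-c2cn3ccnc3c(-c3ccc4ncn(C5CCCCC5)c4c3)n2)c1` is the next compound to be measured. It differs from compound 2 in one place: thiophen-2-yl in place of 2-fluorophenyl on an aromatic carbon. Among the compounds with values here, no measured step swaps the six-membered ring for a five-membered one; the only step known, a number 5.4 percentage points higher from compound 1 to compound 2 (within the scatter), moves a fluorine within the phenyl and is within the scatter, so it bears on the change only by showing how little the read-out responds to variation at this position. A step of no more than the scatter in this assay is therefore expected, in either direction, estimated as a number 3.7 percentage points lower from compound 2 to compound 3 (within the scatter). For compound 3 the expected value in this assay is 25%, with a range from 10% to 42%.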

Compound 3, a percentage reported as inhibition, at one concentration (the size of the read-out at that concentration, not a potency): 17.1%
The estimate for compound 3 lay 7.9 percentage points above the measured number, within the range that was stated.
By their numbers in this assay, from the lowest: compounds 3, 1 and 2 (each within the scatter of the next, the first and the last beyond it).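

In this assay, going by these compounds alone, the change to thiophen-2-yl gives the first step at this aromatic carbon that leaves the scatter, a number 11.6 percentage points lower from compound 2 to compound 3 (beyond the scatter), so the read-out at this position is not as flat as the fluorine shift alone suggested. The same thiophen-2-yl set against 4-fluorophenyl gives a number 6.2 percentage points lower from compound 1 to compound 3 (within the scatter), so the replacement separates from only one of the two fluorophenyl compounds, and the modest step to thiophen-2-yl cannot be read as a general difference between it and fluorophenyl groups. No measurement at hand bears on why the two comparisons differ.

The compounds shown leave open how this position responds to groups of another kind, such as an amine or a carboxylic acid on this aromatic carbon, since only fluorophenyl and thiophen-2-yl groups stand here so far. They also leave open whether an unsubstituted phenyl would read with the fluorophenyl compounds or with thiophen-2-yl, and so what the fluorine itself contributes in either place on the ring.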